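Dienamide series: amide variation and antiproliferative readout

The compounds below may be only part of what the source reports. "The series", "measured", "known", "first", "only" and "open" are said of these compounds alone.

Measured so far:
compound 1 `COc1ccc(CNC(=O)/C=C/C=C/[C@H](O)Cc2ccc(OC)c(OC)c2)cc1` gives 17400 nM
compound 2 `CCN1CCN(C(=O)/C=C/C=C/[C@H](O)Cc2ccc(OC)c(OC)c2)CC1` gives 10800 nM

Both numbers come from a functional assay on IMR-32 cells (Homo sapiens) for antiproliferative activity, read by sulforhodamine B assay, with a stated time of 48 h; on this read-out lower numbers stand for stronger inhibition and higher numbers for weaker inhibition. Compound 2 carries the lower of the two values, yet its gap to compound 1 lies within the scatter, so no order between the two can be claimed. Compound 3 `COc1ccc(C[C@@H](O)/C=C/C=C/C(=O)NCc2ccc(Cl)cc2)cc1OC` is not yet measured. It differs from compound 2 by (4-chlorobenzyl)amino in place of 4-ethylpiperazin-1-yl on a carbonyl carbon. Within the data shown here, no step of this kind has been measured, so the expected step in this assay is taken as a 1.3-fold higher number from compound 2 to compound 3 (0.11 log units; within the scatter), a drift toward a higher number that need not exceed the scatter. Compound 3 is estimated at 14000 nM, within a range of 5000 nM to 40000 nM.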

Compound 3, half-maximal inhibitory concentration: 15700 nM
Compound 3: middle estimate off by 1.1-fold (0.05 log units), on the low side, within the range that was stated.
By their numbers in this assay, from the lowest: compounds 2, 3 and 1 (each within the scatter of the next).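

In this assay, (4-chlorobenzyl)amino in place of 4-ethylpiperazin-1-yl on the carbonyl carbon gives a 1.5-fold higher number from compound 2 to compound 3 (0.16 log units; within the scatter), and chloro in place of methoxy on the aromatic carbon gives a 1.1-fold lower number from compound 1 to compound 3 (0.04 log units; within the scatter). Neither change separates the compounds on this read-out, so the benzylamino and ring-based amide groups shown here remain indistinguishable. No measured evidence bears on this result.

Open, from the compounds shown here alone, is whether morpholin-4-yl on the carbonyl carbon, or a carboxylic acid or dimethylamino group in place of chloro on the aromatic carbon, would move the value beyond the scatter.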